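A few compounds are considered here, and "the series" means these few. Any claim that something is new, unique, unknown or untested is made for them only; others in the source may bear on it.

Measured compounds:
compound 1, `C[C@H](NC(=O)Nc1cccc(C(F)(F)F)c1)c1ccccc1`, 94%
compound 2, `CC(=O)c1cccc(NC(=O)N[C@@H](C)c2ccccc2)c1`, 96%
compound 3, `C[C@H](NC(=O)Nc1cccc(Br)c1)c1ccccc1`, 100%

These three share one core and differ only in the group carried on the aromatic ring. In an ADME assay on the whole organism with Oryza sativa as the target, tested at 0.1 uM (on this read-out lower numbers stand for a stronger effect and higher numbers for a weaker effect at the one concentration tested), compound 1 gives 94%, the lowest of the three numbers, yet all three lie close together: a number 2 percentage points higher from compound 1 to compound 2 (within the scatter), a number 6 percentage points higher from compound 1 to compound 3 (within the scatter) and a number 4 percentage points higher from compound 2 to compound 3 (within the scatter) all stay within the scatter, so no order among them can be claimed.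

Compound 4, `C[C@H](NC(=O)Nc1cc(C(F)(F)F)ccc1F)c1ccccc1`, has not been measured. It differs from compound 1 by fluoro in place of hydrogen on an aromatic carbon.

For the measured compounds named here, no measured step exchanges a hydrogen for a fluoro, so none bears on this change directly. The nearest guide is that every change tried so far on this ring, whether the trifluoromethyl became an acetyl or a bromo, left the read-out within the scatter. A small added fluoro is therefore expected to behave likewise, and the step from compound 1 is expected to be a number 1 percentage points higher from compound 1 to compound 4 (within the scatter), with no clear direction.

For compound 4 in this assay the estimate is 95%, likely between 86% and 100%.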

Compound 4, a percentage reported as activity, at one concentration (the size of the read-out at that concentration, not a potency): 98%
Estimate against measurement, compound 4: 3 percentage points below, within the range that was stated.
By their numbers in this assay, from the lowest: compounds 1, 2, 4 and 3 (each within the scatter of the next).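

For the compounds shown here, compound 4 keeps the trifluoromethyl group of compound 1 and adds a fluoro on an aromatic carbon, ortho to a large group and para to a trifluoromethyl group, whereas the earlier steps only exchanged one ring group for another. In this assay, this addition gives a number 4 percentage points higher from compound 1 to compound 4 (within the scatter), so the ring can carry a second group at this position while the read-out stays within the scatter of compound 1. No separate measurement is available to explain the size of this step.

Fluoro is the only group shown at this position, so it remains open whether an amine or a methoxy group placed there would also stay within the scatter of compound 1. Also open is whether any group on this ring, a carboxylic acid for instance, can move the read-out in this assay beyond the scatter, as every step shown so far stays within it.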